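The source may report more compounds than this note shows. Statements on the series, on what has been measured and on what is new or still open speak of the compounds shown alone.

Measured so far:

- Compound 1, `CCCN(C[C@H]1Cc2c(cccc2N2CCNCC2)CN1)[C@H]1CCCc2cccnc21`: 100%
- Compound 2, `CN(C[C@H]1Cc2c(cccc2N2CCN(C3CC3)CC2)CN1)[C@H]1CCCc2cccnc21`: 15.5%

Compound 1 gives the higher of the two numbers in an ADME assay on microsomes from liver (Homo sapiens) for metabolic stability, read by LC-MS, with a stated time of 10 min; on this read-out lower numbers stand for a less stable compound and higher numbers for a more stable compound; compound 2 sits far lower, and the gap between them lies well beyond the scatter. The two compounds differ in more than one place, so no single change can be read from that gap.

Compound 3, `c1cnc2c(c1)CCC[C@@H]2N(CC1CC1)C[C@H]1Cc2c(cccc2N2CCNCC2)CN1`, is not yet measured in this assay. Relative to compound 1 the change is cyclopropyl in place of ethyl on a saturated chain carbon bound to an amine nitrogen.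

Within the data shown here, no step between measured compounds isolates this change, so the expectation rests on compound 1 alone, whose value in this assay leaves room only for a drop or for no movement. A modest downward step, at most somewhat beyond the scatter, is expected, with no change beyond the scatter a real possibility; the expected step of a number 12 percentage points lower from compound 1 to compound 3 (beyond the scatter) is meant in that sense.

For compound 3 the estimated value in this assay is 88%, with a range from 65% to 100%.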

Compound 3, percent of the compound remaining: 82.1%
Compound 3: the middle estimate sits 5.9 percentage points above what was measured, and the stated range covers the measured number.
By their numbers in this assay, from the lowest: compound 2; then compound 3; then compound 1.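

Among these compounds, the step of a number 17.9 percentage points lower from compound 1 to compound 3 (beyond the scatter) is the first in this assay that isolates a single change, cyclopropyl in place of ethyl on a saturated chain carbon bound to an amine nitrogen. It shows that this position responds to the group placed there, even though compound 3 at 82.1% remains well up the scale of this read-out. Nothing on hand explains the step.

Whether the step follows from the ring or from the added carbon stays open, as the same difference reads propyl to cyclopropylmethyl and no open-chain isobutyl or butyl group is shown for comparison. Compound 2 differs from compound 1 in more than one place, so it does not settle how a methyl group alone would read at this position.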